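Cytotoxicity series where every value so far is a limit

This account rests on a few compounds, and the source may have more. Where it says the series, first, only, none or still open, it means among the compounds named here.

Compound 1 `C=CCSc1nnc(CC)n1N1C(=O)c2ccccc2C1=O`: in a functional assay on MKN-45 cells (Homo sapiens) for cytotoxicity, read by MTT assay, with a stated time of 48 h (on this read-out higher numbers stand for weaker inhibition and lower numbers for stronger inhibition), compound 1 returns only the limit of the assay, > 200000 nM.
Compound 2 `CCc1nnc(SCC(=O)c2ccc(Cl)cc2)n1N1C(=O)c2ccccc2C1=O`: in this assay compound 2 likewise returns only a limit, > 200000 nM.
Compound 3 `C=CCSc1nnc(CCC)n1N1C(=O)c2ccccc2C1=O`: in this assay compound 3 also returns only a limit, > 200000 nM.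

Compound 3 therefore stands nowhere in particular among the numbers shown: it sits at the limit, as do all three measured compounds, which is the limit of > 200000 nM in this assay, at which 3 of the 3 values shown sit. Compound 4 `CCCc1nnc(SCC(=O)c2ccc(Cl)cc2)n1N1C(=O)c2ccccc2C1=O` differs from compound 3 by (4-chlorophenyl)carbonyl in place of vinyl on a saturated chain carbon bound to a sulfur. The same change has been made once before, from compound 1 to compound 2, where it gave a step that the two limits leave unreadable from compound 1 to compound 2. The step that links compound 1 to compound 3 is equally unreadable, a step that the two limits leave unreadable from compound 1 to compound 3. Among the compounds with values here, no measured step in this assay gives a readable size, so no step beyond the scatter can be expected in either direction; the expectation is that compound 4 will again return a limit. The estimated step in this assay is therefore a step that the limit leaves unreadable from compound 3 to compound 4 for compound 4. Compound 4 is expected to come out near 300000 nM, within a range of 100000 nM to 1000000 nM.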

Compound 4, half-maximal inhibitory concentration: > 200000 nM
Compound 4: a limit, no number; the forecaster's own chance of this, stated with the estimate: 85%; the middle value lies beyond the limit too.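

Compound 4 gives only a limit, so its steps from compound 3 and from compound 2 cannot be read in this assay, and the series stands as follows: the limit of > 200000 nM in this assay, at which 4 of the 4 values shown sit.

The compounds shown leave open how far any of them lies beyond that limit, and whether either change alters cytotoxicity at all.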